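Shortening the alkyl amide of compound 3

The compounds below may be only part of what the source reports. "The series", "measured", "known", "first", "only" and "open" are said of these compounds alone.

In an assay on isolated protein for inhibition of aldehyde dehydrogenase 1A1 (Homo sapiens), read by spectrophotometry, tested at 10 uM (on this read-out lower numbers stand for less inhibition and higher numbers for more inhibition at the one concentration tested (going by the name of the read-out)), compound 1 `Cc1cccc(Cn2c(CN3CCN(C(=O)c4ccc(C(F)(F)F)cc4)CC3)nc3ccccc32)c1` gives 22.9% and compound 2 `Cc1cccc(Cn2c(CN3CCN(C(=O)c4cccnc4)CC3)nc3ccccc32)c1` gives 24.5%. Compound 3 `Cc1cccc(Cn2c(CN3CCN(C(=O)C(C)C)CC3)nc3ccccc32)c1` gives 87.2%, the highest of the three numbers. Both steps that reach it, a number 64.3 percentage points higher from compound 1 to compound 3 (beyond the scatter) and a number 62.7 percentage points higher from compound 2 to compound 3 (beyond the scatter), are large and point the same way: an isopropyl on the carbonyl carbon in place of either aryl group lifts inhibition far beyond the scatter. Compound 4 `CC(=O)N1CCN(Cc2nc3ccccc3n2Cc2cccc(C)c2)CC1` differs from compound 3 by methyl in place of isopropyl on a carbonyl carbon. For the measured compounds named here, no measured step exchanges one alkyl group for another on this carbonyl carbon, so the size of this step is not fixed by the data. Compound 4 keeps an alkyl group on the carbonyl carbon, and its inhibition is expected to stay nearer compound 3 at 87.2% than the aryl amides, with room for a moderate drop. Compound 4 is expected to give 75%, in the range 50% to 95%. The expected step is a number 12.2 percentage points lower from compound 3 to compound 4 (beyond the scatter).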

Compound 4, a percentage reported as inhibition, at one concentration (the size of the read-out at that concentration, not a potency): 70.3%
Beside the measured number, compound 4's estimate is 4.7 percentage points above it; the range from low to high includes it.
By their numbers in this assay, from the lowest: compounds 1 and 2 (each within the scatter of the next); then compound 4; then compound 3.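

Replacing one alkyl group with another on this carbonyl carbon costs some inhibition (a number 16.9 percentage points lower from compound 3 to compound 4 (beyond the scatter)), so isopropyl and methyl are not interchangeable here. Methyl nevertheless keeps most of the advantage over the aryl amides (a number 45.8 percentage points higher from compound 2 to compound 4 (beyond the scatter); a number 47.4 percentage points higher from compound 1 to compound 4 (beyond the scatter)), so the large gap does not depend on isopropyl alone. Still open, from the compounds shown here alone, is whether a cyclopropyl or a longer chain such as n-butyl on this carbonyl carbon would match or pass isopropyl, and whether a terminal amine on such a chain would keep the inhibition. No available evidence bears on the cause of these steps.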